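Series notes: halogenated aryloxypropyl variants on the shared core

The source may report more compounds than this note shows. Statements on the series, on what has been measured and on what is new or still open speak of the compounds shown alone.

In an assay on isolated protein for inhibition of Dihydrofolate reductase (Homo sapiens), read by spectrophotometry, using NADPH, with stated times of 5 s and 6 min, tested at 5 uM (on this read-out higher numbers stand for a stronger effect at the one concentration tested and lower numbers for a weaker effect), three compounds of the shared core have been measured. Compound 1 `NC1=NC2(CCOCC2)N(OCCCOc2cccc(Cl)c2Cl)C(N)=N1` gives 81.7%. Compound 2 `NC1=NC2(CCSCC2)N(OCCCOc2cccc(Cl)c2Cl)C(N)=N1` gives 83.8%, and compound 3 `NC1=NC2(CCSCC2)N(OCCCOc2cc(Cl)c(Cl)cc2Cl)C(N)=N1` gives 84.4%. Compound 1 stands lowest of the three numbers; its nearest neighbour is compound 2 and its furthest is compound 3, and both gaps lie within the scatter, so the three read as one level. Among the measured compounds shown here, the only single-point step measured is a number 0.6 percentage points higher from compound 2 to compound 3 (within the scatter), a change of the aryl group on the oxygen on the saturated carbon that stayed within the scatter.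

For the measured compounds named here, compound 4 `NC1=NC2(CCOCC2)N(OCCCOc2ccccc2Br)C(N)=N1` is not yet measured. 2-bromophenyl in place of 2,3-dichlorophenyl on an oxygen on a saturated carbon The step from compound 2 to compound 3 is the one measured change at this place and it stayed within the scatter; no measured step covers the swap of one halogen for another, so the data give no basis for a direction in this assay. Compound 4 is therefore expected to give 78%, within 64% to 88%. The step this estimate means, a number 3.7 percentage points lower from compound 1 to compound 4 (within the scatter), is expected to stay within the scatter.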

Compound 4, a percentage reported as inhibition, at one concentration (the size of the read-out at that concentration, not a potency): 83.8%
Beside the measured number, compound 4's estimate is 5.8 percentage points below it; the range from low to high includes it.
By their numbers in this assay, from the lowest: compounds 1, 2, 4 and 3 (each within the scatter of the next).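

In this assay, among the compounds shown here, 2-bromophenyl in place of 2,3-dichlorophenyl on an oxygen on a saturated carbon gives a number 2.1 percentage points higher from compound 1 to compound 4 (within the scatter), the first measured step at this place in which bromine replaces chlorine and the aryl group carries a different number of halogens. With a number 0.6 percentage points higher from compound 2 to compound 3 (within the scatter), this makes two aryl changes at this place, on two different cores, and neither moves the read-out beyond the scatter, so at the one concentration tested this position tolerates all three halogenated aryl groups shown. No separate measurement bears on this result, so the data give no account of why the level holds.

The compounds shown leave open whether the same level would hold with an unsubstituted phenyl, a carboxylic acid on the aryl ring, an amine on the aryl ring or a longer chain to the aryl oxygen, since every aryl group here is halogenated. They also leave open whether 2-bromophenyl on the core of compound 2 would read at this level, and whether full potency measurements would separate compounds that a single-concentration percentage does not.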